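The source may report more compounds than this note shows. Statements on the series, on what has been measured and on what is new or still open speak of the compounds shown alone.

Compound 3 `CCCc1cc2cn([C@@H]3O[C@H](CO)[C@@H](O)[C@H](O)[C@H]3O)c(=O)nc2o1` carries a propyl chain on a fused bicyclic core. In a functional assay on CCRF-CEM cells (Homo sapiens) for cytotoxicity, with a stated time of 72 h (a higher number here means a weaker inhibitor, a lower number a stronger inhibitor), compound 3 gives 173000 nM, the highest of the two numbers recorded. Compound 1 `CCCCCc1ccc(C#Cc2cn([C@@H]3O[C@H](CO)[C@@H](O)[C@H](O)[C@H]3O)c(=O)nc2O)cc1` gives 81000 nM in this assay. Compound 2 `CC(C)(C)c1ccc(C#Cc2cn([C@@H]3O[C@H](CO)[C@@H](O)[C@H](O)[C@H]3O)c(=O)nc2O)cc1` gives > 250000 nM, which is a limit of this assay rather than a number (the limit of > 250000 nM in this assay, at which 1 of the 3 values shown sits). Within the data shown here, the only step measured here is an at least 3.0-fold higher number from compound 1 to compound 2 (0.48 log units; beyond the scatter), a swap of chain shape on a different core, so it offers little guidance. Compound 4 `CCCCCc1cc2cn([C@@H]3O[C@H](CO)[C@@H](O)[C@H](O)[C@H]3O)c(=O)nc2o1` differs from compound 3 by ethyl in place of hydrogen on a saturated chain carbon, three bonds along the chain from an aromatic carbon, turning propyl into pentyl. Among the measured compounds shown here, with no directly comparable step, only a small change is expected, an estimated step of a 1.6-fold lower number from compound 3 to compound 4 (0.20 log units; within the scatter) for compound 4 in this assay. Compound 4 is therefore expected to give about 110000 nM, between 45000 nM and 250000 nM.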

Compound 4, half-maximal inhibitory concentration: > 250000 nM
Compound 4: no number, only a limit; the forecaster's own chance of this, stated with the estimate: 15%; middle value at least 2.2-fold (0.35 log units) from the limit.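

In this assay compound 4 gives > 250000 nM, which is a limit and not a number, and it is not alone there: the limit of > 250000 nM in this assay, at which 2 of the 4 values shown sit.

Turning propyl into pentyl gives an at least 1.4-fold higher number from compound 3 to compound 4 (0.15 log units; that floor lies within the scatter), so the longer chain shows no gain in strength on this core, although the floor of that step does not establish a real loss.

Going by these compounds, how far compound 4 lies past its limit stays unknown, and so does the true size of this change. On these data alone, whether an amine or a carboxylic acid in place of the propyl chain would give a lower number on this core also remains open.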